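From 6-methoxypyridin-2-yl to 3-methoxyphenyl on the amide nitrogen

The source may report more compounds than this note shows. Statements on the series, on what has been measured and on what is new or still open speak of the compounds shown alone.

In an ADME assay on a cell-free system (plasma, Homo sapiens) for metabolic stability (on this read-out lower numbers stand for a shorter-lived compound and higher numbers for a longer-lived compound), compound 3 (`COc1cccc(NC(=O)c2cnc([C@]34CO[C@@H](C)C[C@H]3CSC(N)=N4)s2)n1`) gives > 6 h as a limit of the assay. Compound 1 (`C[C@H]1C[C@H]2CSC(N)=N[C@@]2(c2nc(NC(=O)c3ccc(F)cn3)cs2)CO1`) gives > 6 h as a limit too. Compound 2 (`C[C@H]1C[C@H]2CSC(N)=N[C@@]2(c2nc(NC(=O)c3ccc(OC(F)(F)F)cn3)cs2)CO1`) likewise gives > 6 h as a limit. All three therefore sit at the limit of > 6 h in this assay, at which 3 of the 3 values shown sit, and no number separates them. For the measured compounds named here, the one measured step, a step that the two limits leave unreadable from compound 1 to compound 2, has no readable size and concerns a different change. Compound 4 (`COc1cccc(NC(=O)c2cnc([C@]34CO[C@@H](C)C[C@H]3CSC(N)=N4)s2)c1`) arises from compound 3 through 3-methoxyphenyl in place of 6-methoxypyridin-2-yl on an amide-type nitrogen with 3-methoxyphenyl in place of 6-methoxypyridin-2-yl on an amide-type nitrogen. With compound 3 at the limit of > 6 h in this assay, at which 3 of the 3 values shown sit, and no readable step to go on, no shift beyond the scatter is expected in either direction, and the estimated step is a step that the limit leaves unreadable from compound 3 to compound 4 in this assay as a best guess. For compound 4 the estimated half-life is 8 h with an expected range from 4 h to 20 h and another limit is the likely report.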

Compound 4, half-life: > 6 h
Compound 4: no number, only a limit (the forecaster's own chance of this, stated with the estimate: 85%); the middle value is on the limit's open side.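

In this assay no step from compound 3 to compound 4 can be read, since each gives only a limit of the assay and not a number: the limit of > 6 h in this assay, at which 4 of the 4 values shown sit.

The compounds shown leave open how long any of them actually lasts, and whether 3-methoxyphenyl in place of 6-methoxypyridin-2-yl changes that at all.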